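The compounds below may be only part of what the source reports. "The series", "measured", "known", "first", "only" and "open" are said of these compounds alone.

Measured so far in a functional assay on A549 cells (Homo sapiens) for inhibition, read by CCK-8 assay, with a stated time of 72 h, tested at 1 uM; a higher number here means a stronger effect of the compound at the concentration tested, a lower number a weaker effect:

Compound 1 `CN(C)C(=O)c1cc2cnc(Nc3ccc(S(=O)(=O)NCCCCCN=C=S)cc3)nc2n1C1CCCC1`: 56.6%
Compound 2 `CN(C)C(=O)c1cc2cnc(Nc3ccc(C(=O)NCCCCN=C=S)cc3)nc2n1C1CCCC1`: 30.2%
Compound 3 `CN(C)C(=O)c1cc2cnc(Nc3ccc(C(=O)NCCCCN=C=S)cc3O)nc2n1C1CCCC1`: 30.3%

Compound 2 stands lowest of the three numbers in this assay. Compound 3 sits within the scatter of it (a number 0.1 percentage points higher from compound 2 to compound 3 (within the scatter)), while the gap to compound 1 is beyond the scatter (a number 26.4 percentage points lower from compound 1 to compound 2 (beyond the scatter)).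

Compound 4 `CN(C)C(=O)c1cc2cnc(Nc3ccc(NC(=O)CCCCN=C=S)cc3)nc2n1C1CCCC1` is not yet measured. It differs from compound 2 by a group of 10 heavy atoms (6 carbon, 2 nitrogen, 1 oxygen, 1 sulfur; no ring) in place of a group of 10 heavy atoms (6 carbon, 2 nitrogen, 1 oxygen, 1 sulfur; no ring), on an aromatic carbon; the two have the same atoms, joined differently.

Neither measured step bears on this change: the step from compound 1 to compound 2 swaps one group for another of a different size, and the step from compound 2 to compound 3 adds a hydroxy. Nothing among the three compounds shows what rejoining the same atoms does, so no step beyond the scatter is expected: a number 0.2 percentage points lower from compound 2 to compound 4 (within the scatter). For compound 4 the estimate is 30%, within 16% to 46%.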

Compound 4, a percentage reported as inhibition, at one concentration (the size of the read-out at that concentration, not a potency): 38.2%
The estimate for compound 4 lay 8.2 percentage points below the measured number; low and high end bracket the measured number.
By their numbers in this assay, from the lowest: compounds 2, 3 and 4 (each within the scatter of the next); then compound 1.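

In this assay rejoining the same atoms on this aromatic carbon, para to a large group, gives a number 8 percentage points higher from compound 2 to compound 4 (within the scatter) and so does not separate the two arrangements. The group of compound 1 also stands apart from this second arrangement, with a number 18.4 percentage points lower from compound 1 to compound 4 (beyond the scatter) as the step, so its gap is seen against both groups of 10 heavy atoms. Nothing measured here accounts for either step.

Still open, going by these compounds, is how a longer chain on the arrangement of compound 4 would read. Also open, on these data alone, is what an amine or a carboxylic acid at the chain end, in place of the isothiocyanate, would do.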